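Chain substituents on the aromatic nitrogen: inhibition series

A few compounds are considered here, and "the series" means these few. Any claim that something is new, unique, unknown or untested is made for them only; others in the source may bear on it.

Measured so far in an assay on NK92 cells for inhibition of interleukin-2 (Homo sapiens), read by AlphaScreen, with stated times of 30 min and 1 h; on this read-out lower numbers stand for stronger inhibition and higher numbers for weaker inhibition:
- compound 1 `Cn1c(Cc2nn(C)c(=O)c3ccccc23)nnc1SCCCCCCCC(=O)Nc1ccc(Cl)cc1Cl`: 350 nM
- compound 2 `Cn1nc(Cc2nnc(SCCCCCCCC(=O)Nc3ccc(Cl)cc3Cl)n2CCC=O)c2ccccc2c1=O`: 960 nM
- compound 3 `Cn1nc(Cc2nnc(SCCCCCCCC(=O)Nc3ccc(Cl)cc3Cl)n2CCCO)c2ccccc2c1=O`: reported only as a limit, > 30000 nM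

Compound 1 holds the lowest of the two numbers shown; the nearest is compound 2, with a 2.7-fold higher number from compound 1 to compound 2 (0.44 log units; beyond the scatter). For compound 3 the value is a limit of this assay and not a number (the limit of > 30000 nM in this assay, at which 1 of the 3 values shown sits).

Compound 4 `Cn1c(Cc2nn(CCC(=O)O)c(=O)c3ccccc23)nnc1SCCCCCCCC(=O)Nc1ccc(Cl)cc1Cl` differs from compound 1 by carboxymethyl in place of hydrogen on a saturated chain carbon bound to an aromatic nitrogen. Going by the values given here, three measured steps bear on it, all placing a chain on the same saturated carbon bound to the aromatic nitrogen: a 2.7-fold higher number from compound 1 to compound 2 (0.44 log units; beyond the scatter) was modest, whereas an at least 85-fold higher number from compound 1 to compound 3 (1.93 log units; beyond the scatter) and an at least 31-fold higher number from compound 2 to compound 3 (1.49 log units; beyond the scatter) were large. Every chain added at this place has raised the number, and the hydroxyl-bearing chain did so most. The carboxymethyl group entering in compound 4 likewise carries a hydrogen-bond donor and acceptor, so a higher number is expected, between the modest and the large cases seen.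

Compound 4 is therefore estimated at 4000 nM in this assay, expected range 800 nM to 25000 nM, a step of an 11-fold higher number from compound 1 to compound 4 (1.06 log units; beyond the scatter).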

Compound 4, half-maximal inhibitory concentration: 30000 nM
The estimate for compound 4 lay 7.5-fold (0.88 log units) below the measured number, outside the stated range (above it).
By their numbers in this assay, from the lowest: compound 1; then compound 2; then compound 4.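

Carboxymethyl on this saturated chain carbon bound to an aromatic nitrogen gives a large change in this assay, an 86-fold higher number from compound 1 to compound 4 (1.93 log units; beyond the scatter), so the modest result for formylmethyl, a 2.7-fold higher number from compound 1 to compound 2 (0.44 log units; beyond the scatter), does not extend to every chain placed here. Going by these compounds alone, compound 4 also gives a large step as a measured number, so the size of such a change can be read directly for the first time. Compound 3 remains a limit and not a number: the limit of > 30000 nM in this assay, at which 1 of the 4 values shown sits.

The compounds shown leave open whether a plain ethyl chain, an amine-ending chain or a methyl ester at this place would stay closer to compound 1, at 350 nM. They also cannot separate the contribution of chain length from that of the group at the chain end.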